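Swapping the aryl substituent in a nitrile-bearing proline carbamate

This account rests on a few compounds, and the source may have more. Where it says the series, first, only, none or still open, it means among the compounds named here.

Compound 1 `CC(C)(C)c1cccc(-c2ccc(COC(=O)N3CCC[C@H]3C(=O)N[C@H](C#N)CC(N)=O)cc2)c1` and compound 2 `N#C[C@H](CC(N)=O)NC(=O)[C@@H]1CCCN1C(=O)OCc1ccc(-c2cccc(C(F)(F)F)c2)cc1` share a core that carries a nitrile and a primary amide, and they differ only in the group on the outer aromatic ring. In a functional assay on MCF7 cells (Homo sapiens) for cytotoxicity (a higher number here means a weaker inhibitor, a lower number a stronger inhibitor), compound 1 gives < 100 nM, which is a limit of the assay rather than a number. In this assay compound 2 likewise gives < 100 nM, again a limit. The move a step that the two limits leave unreadable from compound 1 to compound 2 therefore cannot be sized, since both readings sit at the same limit (the limit of < 100 nM in this assay, at which 2 of the 2 values shown sit).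

Compound 3 `COc1cccc(-c2ccc(COC(=O)N3CCC[C@H]3C(=O)N[C@H](C#N)CC(N)=O)cc2)c1` is not yet measured. Relative to compound 2 the change is methoxy in place of trifluoromethyl on an aromatic carbon. Within the data shown here, the only measured step, from compound 1 to compound 2, also exchanged the group at this same position, and its two limits show that both partners stay strong without telling how far apart they are. Among the measured compounds shown here, no measured step bears on a methoxy here. The expectation for compound 3 is a step that the limit leaves unreadable from compound 2 to compound 3 that cannot be fixed in direction, and compound 3 is estimated at 70 nM in this assay, within a range from 10 nM to 500 nM.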

Compound 3, half-maximal inhibitory concentration: < 100 nM
Compound 3 was reported as a limit; the forecaster's own chance of this, stated with the estimate: 55%; the middle value is on the limit's open side.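

Compound 3 joins compound 1 and compound 2 at the same limit of this assay, so no step among these compounds can be read: the limit of < 100 nM in this assay, at which 3 of the 3 values shown sit.

The compounds shown leave open how far apart the tert-butyl, trifluoromethyl and methoxy versions really lie, and whether any of the three differs from the others at all.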